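Widening the amine from diethylamino to diisopropylamino

The compounds below may be only part of what the source reports. "The series", "measured", "known", "first", "only" and "open" are said of these compounds alone.

In a functional assay on A549 cells (Homo sapiens) for antiproliferative activity, read by MTT assay, with a stated time of 48 h (a higher number here means a weaker inhibitor, a lower number a stronger inhibitor), compound 1 `CC(C)=CCC[C@]1(C)/C=C/[C@@H](OC(=O)C=C(C)C)[C@](C)(O)/C=C/C(=O)/C(CN(C)C)=C\C1` gives 590 nM and compound 2 `CCN(CC)C/C1=C/C[C@](C)(CCC=C(C)C)/C=C/[C@@H](OC(=O)C=C(C)C)[C@](C)(O)/C=C/C1=O` gives 130 nM as the lower of the two numbers. Compound 3 `CC(C)=CCC[C@]1(C)/C=C/[C@@H](OC(=O)C=C(C)C)[C@](C)(O)/C=C/C(=O)/C(CN(C(C)C)C(C)C)=C\C1` differs from compound 2 by diisopropylamino in place of diethylamino on a saturated chain carbon bound to a double-bonded ring carbon is the whole change. Among the measured compounds shown here, one measured step bears on it, the exchange of dimethylamino for diethylamino at that place: a 4.5-fold lower number from compound 1 to compound 2 (0.66 log units; beyond the scatter) is modest and beyond the scatter. One step sets no trend, so only a small further fall, within the scatter, is expected in this assay here. The expected step is a 1.2-fold lower number from compound 2 to compound 3 (0.07 log units; within the scatter) by this estimate. The estimated value for compound 3 is 110 nM with an expected range of 40 nM to 320 nM in this assay.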

Compound 3, half-maximal inhibitory concentration: 650 nM
Compound 3: middle estimate off by 5.9-fold (0.77 log units), on the low side; the whole stated range lies below it.
By their numbers in this assay, from the lowest: compound 2; then compounds 1 and 3 (each within the scatter of the next).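

In this assay the earlier fall does not continue past diethylamino: there is a 5.0-fold higher number from compound 2 to compound 3 (0.70 log units; beyond the scatter) and so the number does not move in one direction across dimethylamino, diethylamino and diisopropylamino. With a 1.1-fold higher number from compound 1 to compound 3 (0.04 log units; within the scatter) the dimethylamino and diisopropylamino compounds stand level, and compound 2 alone has the lowest number. Nothing available here explains this turn.

On these data alone, whether a ring amine such as pyrrolidine or morpholine, or a mixed ethyl isopropyl amine, would match compound 2 remains open. Also open, as far as these compounds go, is whether the same order of amines would hold with a different ester on the shared core.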